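Adding a fluoro group to compound 3

The source may hold more compounds than are shown below. What is called first, only, known or untested is meant among the compounds shown, and "the series" means these compounds.

Compound 1 `O=C(NS(=O)(=O)c1ccccc1)c1cccnc1`: 11500 nM
Compound 2 `O=C(NS(=O)(=O)c1ccc(F)cc1)c1ccncc1`: 13900 nM
Compound 3 `O=C(NS(=O)(=O)c1ccccc1)c1ccccn1`: 10600 nM

These three values come from a functional assay on MCF7 cells (Homo sapiens) for antiproliferative activity, read by colorimetric assay and MTT assay, with a stated time of 48 h; a higher number here means a weaker inhibitor, a lower number a stronger inhibitor. Compound 3 gives 10600 nM, which lies within the usual scatter of the values of both other compounds, so the three cannot be ranked.

The unmeasured compound 4 `O=C(NS(=O)(=O)c1ccc(F)cc1)c1ccccn1` differs from compound 3 by a single change: fluoro in place of hydrogen on an aromatic carbon. This is fluoro in place of hydrogen on an aromatic carbon, para to a large group.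

Among the compounds with values here, the one measured step, a 1.1-fold lower number from compound 1 to compound 3 (0.04 log units; within the scatter), does not involve fluoro, so it offers only indirect guidance. Within the data shown here, no measured pair isolates the fluoro change. Still, compound 2, which carries a fluoro group, gives 13900 nM, within the scatter of the value of compound 3. Little movement is therefore expected in this assay, and nothing beyond the scatter. The estimated step is a 1.1-fold higher number from compound 3 to compound 4 (0.04 log units; within the scatter). For compound 4 the estimated value is 11500 nM, with an expected range from 6500 nM to 20000 nM.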

Compound 4, half-maximal inhibitory concentration: 11000 nM
The estimate for compound 4 lay 1.0-fold (0.02 log units) above the measured number; low and high end bracket the measured number.
By their numbers in this assay, from the lowest: compounds 3, 4, 1 and 2 (each within the scatter of the next).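

Fluoro in place of hydrogen on an aromatic carbon, para to a large group, now has a measured pair of its own in this assay (a 1.0-fold higher number from compound 3 to compound 4 (0.02 log units; within the scatter)), so at this place the change cannot be told from the scatter. With fluoro present on both compounds, the other new single change also stays within the scatter (a 1.3-fold lower number from compound 2 to compound 4 (0.10 log units; within the scatter)). No measurement at hand offers an explanation for these results.

Going by these compounds, whether a bigger group at this same place, such as a methoxy group, a trifluoromethyl group or an amine, would move the number beyond the scatter stays open. All four numbers also come from a single cell line, so whether other cells would respond in the same way is open too.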